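Replacing the aryl group of compound 2

The compounds below may be only part of what the source reports. "The series", "measured", "known", "first", "only" and "open" are said of these compounds alone.

- compound 1 `COc1ccc(-c2ccc3c(c2)C(=O)C(=O)N3Cc2ccc(OC)c(OC)c2)cc1`: 60 nM
- compound 2 `COc1ccc(CN2C(=O)C(=O)c3cc(-c4ccc(OC)c(OC)c4)ccc32)cc1`: 260 nM

For the measured compounds named here, in a functional assay on K562 cells (Homo sapiens) for antiproliferative activity, read by MTT assay, with a stated time of 48 h (a lower number here means a stronger inhibitor, a higher number a weaker inhibitor), compound 2 gives 260 nM, the higher of the two numbers so far. Compound 1 stands lower at 60 nM, and that gap lies beyond the usual scatter. The two measured compounds do not differ in one place only, so no measured single change is available as a guide.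

Compound 3 `COc1ccc(CN2C(=O)C(=O)c3cc(-c4ccc(OC(C)C)cc4)ccc32)cc1` departs from compound 2 at one place: 4-isopropoxyphenyl in place of 3,4-dimethoxyphenyl on an aromatic carbon, (4-isopropoxyphenyl in place of 3,4-dimethoxyphenyl on an aromatic carbon). The group that enters has the same number of heavy atoms as the one that leaves, but the data say nothing direct about this replacement. The expectation therefore stays close to compound 2, with a slight lean towards the lower number seen for compound 1 at 60 nM. The expected change is small and within the usual scatter, a 1.3-fold lower number from compound 2 to compound 3 (0.11 log units; within the scatter). For compound 3 the estimated value is 200 nM, with an expected range of 70 nM to 600 nM.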

Compound 3, half-maximal inhibitory concentration: 310 nM
Compound 3: the middle estimate sits 1.6-fold (0.19 log units) below what was measured, within the range that was stated.
By their numbers in this assay, from the lowest: compound 1; then compounds 2 and 3 (each within the scatter of the next).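

At the aromatic carbon of the shared core that carries the aryl group, this assay gives a 1.2-fold higher number from compound 2 to compound 3 (0.08 log units; within the scatter) for the exchange of 3,4-dimethoxyphenyl for 4-isopropoxyphenyl, so the two groups are not separated here. For the compounds shown here, this is the first single-place step: with the rest of compound 2 held fixed, an exchange that keeps the count of heavy atoms and goes from two hydrogen-bond acceptors to one in the group leaves the read-out inside the scatter. No measurement at hand bears on why these two groups read alike, so the step stands as an observation only.

Open, from the compounds shown here alone, is whether the aromatic carbon stays this undemanding with a group of another kind, such as a dimethylamino group or a carboxylic acid on the phenyl ring, or a longer chain such as hexyloxy in place of isopropoxy. Also open, going by these compounds, is whether the same exchange would read alike on compound 1, since one step on compound 2 does not carry over to a different substitution elsewhere on the core.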